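The compounds below may be only part of what the source reports. "The series", "measured", "known", "first", "only" and "open" are said of these compounds alone.

Measured so far in a functional assay on SK-N-AS cells (Homo sapiens) for antiproliferative activity, with a stated time of 72 h; on this read-out lower numbers stand for stronger inhibition and higher numbers for weaker inhibition:
- compound 1 `Cc1ccc(CNC(=O)CCN(Cc2ccc(C(=O)NO)cc2)C(=O)c2ccc(N(C)C)cc2)cc1`: 340 nM
- compound 2 `CN(C)c1ccc(C(=O)N(CCC(=O)NCc2ccccc2)Cc2ccc(C(=O)NO)cc2)cc1`: 1420 nM

Within the data shown here, compound 2 holds the higher of the two numbers, and compound 1 is its only neighbour. The next structure is compound 3 `Cc1ccc(NC(=O)CCN(Cc2ccc(C(=O)NO)cc2)C(=O)c2ccc(N(C)C)cc2)cc1`, which differs from compound 2 as follows: 4-methylphenyl in place of benzyl on an amide-type nitrogen. In words, this is 4-methylphenyl in place of benzyl on an amide-type nitrogen.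

Among the measured compounds shown here, one measured step bears on this change. Hydrogen in place of methyl on an aromatic carbon gives a 4.2-fold higher number from compound 1 to compound 2 (0.62 log units; beyond the scatter), a modest step beyond the scatter. For the measured compounds named here, compound 3 carries a methyl again, but no measured pair shows what replacing benzyl itself does. A smaller step towards a lower number is therefore expected in this assay. The expected step is a 2.2-fold lower number from compound 2 to compound 3 (0.34 log units; beyond the scatter). For compound 3 the estimate is 650 nM, with an expected range of 200 nM to 1900 nM.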

Compound 3, half-maximal inhibitory concentration: 400 nM
Compound 3: the middle estimate sits 1.6-fold (0.21 log units) above what was measured; low and high end bracket the measured number.
By their numbers in this assay, from the lowest: compounds 1 and 3 (each within the scatter of the next); then compound 2.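

In this assay, among these compounds, the position on the amide-type nitrogen now tolerates a second kind of substituent: 4-methylphenyl in place of benzyl gives a 3.6-fold lower number from compound 2 to compound 3 (0.55 log units; beyond the scatter) and shows that benzyl is not the only group here to compare against. The more telling comparison is 4-methylphenyl in place of 4-methylbenzyl, which gives a 1.2-fold higher number from compound 1 to compound 3 (0.07 log units; within the scatter) and so does not separate the two methyl-bearing groups, leaving compound 2 alone at the higher number. Nothing available explains either step.

Going by these compounds, the step from compound 2 to compound 3 changes both the methyl and the attachment of the ring, so how much each part contributes remains open. Plain phenyl would separate the two, and 2-phenylethyl would show whether a longer chain on this nitrogen keeps the read-out where it stands.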